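Adding a methoxy group to compound 1

This account rests on a few compounds, and the source may have more. Where it says the series, first, only, none or still open, it means among the compounds named here.

Going by the values given here, in a functional assay on the whole organism for inhibition, with Rattus norvegicus as the target (on this read-out higher numbers stand for an effect only at larger amounts of compound and lower numbers for an effect already at smaller amounts), compound 1 `CC(C)c1ccc(OC(Cc2ccccc2)C(=O)O)cc1` gives 50 mg/kg, the higher of the two exact numbers so far. Compound 2 `CC(C)c1ccc(OC(Cc2ccc(C(F)(F)F)cc2)C(=O)O)cc1` gives 10 mg/kg. Compound 3 `Cc1ccc(CC(Oc2ccc(C(C)C)cc2)C(=O)O)cc1` gives < 50 mg/kg, which is a limit and not a number. Compound 4 `COc1ccccc1CC(Oc1ccc(C(C)C)cc1)C(=O)O` differs from compound 1 by methoxy in place of hydrogen on an aromatic carbon, with methoxy in place of hydrogen on an aromatic carbon, ortho to a large group. Going by these compounds, the two measured replacements of hydrogen on an aromatic carbon point the same way: a 5.0-fold lower number from compound 1 to compound 2 (0.70 log units; beyond the scatter), a modest step, and a number no higher from compound 1 to compound 3 (the limit leaves the size open), whose size stays open. A small move towards a lower number is therefore expected, giving a 1.7-fold lower number from compound 1 to compound 4 (0.22 log units; within the scatter). Compound 4 is estimated at 30 mg/kg, with an expected range of 10 mg/kg to 80 mg/kg.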

Compound 4, dose for half-maximal effect: > 10 mg/kg
Compound 4 was reported as a limit (the forecaster's own chance of this, stated with the estimate: 30%); the middle value is on the limit's open side.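

Compound 4 is reported only as a limit, so the step from compound 1 to compound 4 cannot be read. The compounds shown leave open whether methoxy in place of hydrogen shifts the half-maximal dose, and in which direction.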